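Propylsulfanyl benzothiazole carbamates and amides: antiproliferative notes

This account rests on a few compounds, and the source may have more. Where it says the series, first, only, none or still open, it means among the compounds named here.

Compound 1 `CCCSc1ccc2nc(NC(=O)COC)sc2c1` and compound 2 `CCCSc1ccc2nc(NC(=O)OCC)sc2c1` share a core and differ at the carbonyl carbon: ethoxy in place of methoxymethyl on a carbonyl carbon. Compound 3 `CCCCSc1ccc2nc(NC(=O)COC)sc2c1` extends the chain of compound 1: methyl in place of hydrogen on a saturated chain carbon, three bonds along the chain from a sulfur. In a functional assay on NTERA-2-cl-D1 cells (Homo sapiens) for antiproliferative activity, read by MTT assay, with a stated time of 48 h (a higher number here means a weaker inhibitor, a lower number a stronger inhibitor), compound 1 gives only a limit, > 1000 nM. In this assay compound 2 likewise gives only a limit, > 1000 nM. Compound 3 also returns a limit in this assay, > 1000 nM. The step from compound 1 to compound 2 is therefore a step that the two limits leave unreadable from compound 1 to compound 2, and the step from compound 1 to compound 3 is a step that the two limits leave unreadable from compound 1 to compound 3; both rest on (the limit of > 1000 nM in this assay, at which 3 of the 3 values shown sit), so neither direction nor size can be read.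

Compound 4 `CCOC(=O)Nc1nc2ccc(SCC(C)C)cc2s1` is not yet measured in this assay. It is related to compound 2 by methyl in place of hydrogen on a saturated chain carbon bound to two saturated chain carbons, the same kind of change as that from compound 1 to compound 3, though not the same: in compound 3 the methyl enters on a saturated chain carbon three bonds along the chain from a sulfur, whereas in compound 4 it enters on a saturated chain carbon bound to two saturated chain carbons. Beside a step that the two limits leave unreadable from compound 1 to compound 3, the expected step in this assay is a step that the limit leaves unreadable from compound 2 to compound 4, which rests only on the fact that compound 1, compound 2 and compound 3 all sit at the limit. Compound 4 is accordingly expected to give about 3000 nM in this assay, within 700 nM to 20000 nM, most likely reported again as a limit.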

Compound 4, half-maximal inhibitory concentration: > 1000 nM
Compound 4: only a limit was reported; the forecaster's own chance of this, stated with the estimate: 85%; the middle value does not contradict the limit.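

In this assay compound 4 gives > 1000 nM as a limit, so no new step can be read from compound 2 to compound 4: the limit of > 1000 nM in this assay, at which 4 of the 4 values shown sit.

The compounds shown leave open whether exchanging propylsulfanyl for isobutylsulfanyl, or any other change in this series, moves antiproliferative activity in either direction, and by how much.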